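A few compounds are considered here, and "the series" means these few. Any claim that something is new, unique, unknown or untested is made for them only; others in the source may bear on it.

Measured so far: compound 1 `Cn1cc2c(Cl)nc(NC(=O)c3ccc(F)cc3)nc2n1` and compound 2 `CC(C)n1cc2c(Cl)nc(NC(=O)c3ccc(C(F)(F)F)cc3)nc2n1`.

In an assay on CHO cells for displacement of a labelled ligand from adenosine receptor A1 (Homo sapiens), read by scintillation counting, with a stated time of 3 h (on this read-out lower numbers stand for stronger inhibition and higher numbers for weaker inhibition), compound 2 gives 13800 nM. Compound 1 reaches only a limit of the assay, > 100000 nM. Within the data shown here, compound 2 is thus the only compound with a number, and compound 1 sits at the limit of > 100000 nM in this assay, at which 1 of the 2 values shown sits. Compound 3 `CC(C)n1cc2c(Cl)nc(NC(=O)c3ccc(F)cc3)nc2n1` differs from compound 2 in one place: fluoro in place of trifluoromethyl on an aromatic carbon. Among the measured compounds shown here, no measured pair shows this change, so its size is uncertain. The step of a 2.5-fold higher number from compound 2 to compound 3 (0.40 log units; beyond the scatter) is expected to be a loss of potency beyond the usual scatter. Compound 3 is estimated at 35000 nM, likely between 8000 nM and 150000 nM, with a fair chance that only a limit is reported.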

Compound 3, inhibition constant: 3400 nM
Estimate against measurement, compound 3: 10-fold (1.01 log units) above, and the stated range ends above it.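

In this assay, fluoro in place of trifluoromethyl on the aromatic carbon gives a 4.1-fold lower number from compound 2 to compound 3 (0.61 log units; beyond the scatter), so the group at this place changes the reading, and fluoro is the better of these two. With fluoro kept, isopropyl in place of methyl on the aromatic nitrogen gives an at least 29-fold lower number from compound 1 to compound 3 (1.46 log units; beyond the scatter). That step starts from a limit of the assay, not a number: the limit of > 100000 nM in this assay, at which 1 of the 3 values shown sits.

From the compounds shown here alone, whether a methoxy group or a nitrile at that ring carbon would lower the number further remains open. So does whether an ethyl group or a longer chain on the nitrogen would do better than isopropyl.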